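The source may hold more compounds than are shown below. What is called first, only, known or untested is meant among the compounds shown, and "the series" means these compounds.

Of the compounds shown here, two have so far been read in a functional assay on EKVX cells (Homo sapiens) for cytotoxicity, read by sulforhodamine B assay, with a stated time of 48 h, tested at 100 nM; a higher number here means a weaker effect of the compound at the concentration tested, a lower number a stronger effect. Compound 1 `COc1cc(C)cc(-c2c(-c3ccnc(-c4ccc(C(C)=O)cc4)c3)cnn2CC#N)c1` gives 91% in this assay. Compound 2 `Cc1cc(O)cc(-c2nn(CC#N)cc2-c2ccnc(-c3ccc(Oc4ccccc4)cc3)c2)c1` gives 77% in this assay, the lower of the two numbers, and the gap to compound 1 lies beyond the usual scatter. Compound 3 `Cc1cc(O)cc(-c2nn(CC#N)cc2-c2ccnc(-c3ccc(N(C)C)cc3)c2)c1` has not been measured; it differs from compound 2 in one place: dimethylamino in place of phenoxy on an aromatic carbon. Going by the values given here, no measured pair shows the effect of such a change. The step from compound 2 to compound 3 is expected to be small, towards a weaker effect, likely within the scatter, at a number 8 percentage points higher from compound 2 to compound 3 (within the scatter). Compound 3 is therefore estimated at 85%, within a range from 70% to 100%.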

Compound 3, a percentage reported as activity, at one concentration (the size of the read-out at that concentration, not a potency): 81%
Estimate against measurement, compound 3: 4 percentage points above, and the stated range covers the measured number.
By their numbers in this assay, from the lowest: compounds 2, 3 and 1 (each within the scatter of the next, the first and the last beyond it).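

In this assay, dimethylamino in place of phenoxy gives a number 4 percentage points higher from compound 2 to compound 3 (within the scatter) on this aromatic carbon, para to a large group. This first direct reading at the position shows that a group of 7 heavy atoms with an aromatic ring can give way to one of 3 heavy atoms with no ring without a step beyond the scatter. Nothing at hand accounts for this result. As far as these compounds go, whether a carboxylic acid, a primary amine or a longer alkoxy chain here would move the number beyond the scatter stays open. So does whether the same exchange would read alike on the core of compound 1.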